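Cytotoxicity notes on an anilino-to-ethylamino pair

The source may hold more compounds than are shown below. What is called first, only, known or untested is meant among the compounds shown, and "the series" means these compounds.

Measured so far in an ADME assay on TERT-RPE1 cells (Homo sapiens) for cytotoxicity, read by resazurin assay, with a stated time of 48 h; a higher number here means a weaker inhibitor, a lower number a stronger inhibitor:
Compound 1 `CCOc1ccc(NC(=O)c2c(N)n[nH]c2Nc2ccccc2)cc1` gives 67800 nM.
Compound 2 `CCOc1ccc(-n2nnc3n[nH]c(Nc4ccccc4)c3c2=O)cc1` gives only a limit of the assay, > 100000 nM.
Compound 3 `CCNc1[nH]nc(N)c1C(=O)Nc1ccc(OCC)cc1` gives only a limit of the assay, > 100000 nM.

The change from compound 1 to compound 3 is ethyl in place of phenyl on a nitrogen on an aromatic ring. It gave an at least 1.4-fold higher number from compound 1 to compound 3 (0.16 log units; that floor lies within the scatter), a floor set by the limit of > 100000 nM in this assay, at which 2 of the 3 values shown sit. Compound 2 and compound 1 differ in more than one place; how the two cores differ is not broken down here. Compound 4 `CCNc1[nH]nc2nnn(-c3ccc(OCC)cc3)c(=O)c12` is not yet measured in this assay; it stands to compound 2 as compound 3 stands to compound 1, by the same change, (ethyl in place of phenyl on a nitrogen on an aromatic ring). Compound 4 is expected to give a step that the limit leaves unreadable from compound 2 to compound 4. That expectation rests on compound 2 sitting at the limit of this assay, > 100000 nM. It rests also on the earlier step, an at least 1.4-fold higher number from compound 1 to compound 3 (0.16 log units; that floor lies within the scatter), itself only a floor. Compound 4 is therefore estimated at 150000 nM, most likely reported again only as a limit, within 80000 nM to 400000 nM.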

Compound 4, half-maximal inhibitory concentration: > 100000 nM
Compound 4 ended at the assay's limit; the forecaster's own chance of this, stated with the estimate: 85%; the middle value is on the limit's open side.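

Compound 2 and compound 4 both stand only as limits of the assay, so no step can be read between them: the limit of > 100000 nM in this assay, at which 3 of the 4 values shown sit.

The compounds shown leave open whether anilino to ethylamino changes the number at all on the core of compound 2.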